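The source may report more compounds than this note shows. Statements on the series, on what has been measured and on what is new or still open speak of the compounds shown alone.

Measured compounds:
- compound 1, `O=C(CC(c1ccc(F)cc1)C(C(=O)Nc1ccccn1)C(=O)Nc1ccccn1)c1ccccc1`: "not active" (no number reported)
- compound 2, `O=C(CC(c1ccccc1)C(C(=O)Nc1ccccn1)C(=O)Nc1ccccn1)c1ccc(F)cc1`: "not active" (no number reported)
- compound 3, `O=C(CC(c1ccc(F)cc1)C(C(=O)Nc1ccccn1)C(=O)Nc1ccccn1)c1ccc(F)cc1`: 20100 nM

All three share one core and differ only in the halogen pattern on their two outer phenyl rings. In a functional assay on NCI-H460 cells (Homo sapiens) for inhibition, read by MTT assay, with a stated time of 48 h (a higher number here means a weaker inhibitor, a lower number a stronger inhibitor), compound 1 gives "not active" (no number reported), so no number stands for it, and compound 2 likewise gives "not active" (no number reported). Within the data shown here, only compound 3 gives a number in this assay, 20100 nM, and that number is high, so even the one compound with a reading is a weak inhibitor. Compound 1 therefore stands at the inactive end of what has been measured.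

Compound 4, `O=C(CC(c1ccc(Cl)cc1Cl)C(C(=O)Nc1ccccn1)C(=O)Nc1ccccn1)c1ccccc1`, is the next step from compound 1: 2,4-dichlorophenyl in place of 4-fluorophenyl on a saturated chain carbon bound to two saturated chain carbons. Among the measured compounds shown here, no measured pair shows what this change does, so the direction is open. The outcome for compound 4 in this assay is expected to stay in the weak range, with a fair chance that no number is reported at all. Its value is estimated at 25000 nM, with a range from 7000 nM to 90000 nM.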

Compound 4, half-maximal inhibitory concentration: 13100 nM
The estimate for compound 4 lay 1.9-fold (0.28 log units) above the measured number, within the range that was stated.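

Compound 1 has no number to compare with compound 4, which gives 13100 nM in this assay, so no step can be read between them. Nothing shown offers an explanation for this result. As far as these compounds go, what 2,4-dichlorophenyl in place of 4-fluorophenyl does to potency remains open.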